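A few compounds are considered here, and "the series" means these few. Any claim that something is new, unique, unknown or untested is made for them only; others in the source may bear on it.

Compound 1 `CO[C@@H](C(=O)N[C@H]1CCCCNC1=O)[C@@H]1OC(C)(C)O[C@H](/C=C/C(C)(C)C)[C@@H]1O`: > 150000 nM
Compound 2 `CO[C@@H](C(=O)N[C@@H]1CC[C@H](O)CNC1=O)[C@H](O)[C@@H](O)[C@H](O)/C=C/C(C)(C)C`: 80400 nM

Both compounds were tested in a functional assay on MCF7 cells (Homo sapiens) for cytotoxicity, read by colorimetric assay and neutral red uptake, with a stated time of 72 h; a lower number here means a stronger inhibitor, a higher number a weaker inhibitor. Compound 1 gives only a limit and not a number: > 150000 nM. This is the limit of > 150000 nM in this assay, at which 1 of the 2 values shown sits, so its true position cannot be read from the data. Going by the values given here, compound 2 does give a number, 80400 nM, but no measured pair here differs in just one place.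

Compound 3 `CO[C@@H](C(=O)N[C@@H]1CCCCNC1=O)[C@@H]1OC(C)(C)O[C@H](/C=C/C(C)(C)C)[C@@H]1O` has not yet been measured. Set against compound 1, (the two compounds have the same atoms and bonds and differ only in configuration as drawn: 1 of 6 stereo elements differ; a stereocentre at a saturated ring carbon is drawn S in compound 1 and R in compound 3). Nothing leaves or enters, and only the spatial arrangement at that one ring carbon is reversed.

Among the compounds with values here, no measured pair shows how much such a reversal matters, so the closest guide is compound 1 at > 150000 nM. Weak activity is therefore expected again, with no step beyond the usual scatter and no firm direction. The expected step is an at least 1.1-fold lower number from compound 1 to compound 3 (0.06 log units; that floor lies within the scatter). For compound 3 the estimated value is 130000 nM, with an expected range from 50000 nM to 300000 nM. A report of only a limit is the more likely outcome.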

Compound 3, half-maximal inhibitory concentration: > 150000 nM
Compound 3: a limit, no number (the forecaster's own chance of this, stated with the estimate: 65%); middle value at least 1.1-fold (0.06 log units) away from the limit.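

In this assay compound 3 gives only a limit, > 150000 nM. No step between compound 1 and compound 3 can be read, since both compounds stop at the same limit: the limit of > 150000 nM in this assay, at which 2 of the 3 values shown sit.

Still open, from the compounds shown here alone, is whether reversing the stereocentre at that saturated ring carbon changes activity at all in this assay, with no number yet for either compound.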